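Replacing Cyano with 1H-Benzimidazol-2-yl: An Expected Step

The source may report more compounds than this note shows. Statements on the series, on what has been measured and on what is new or still open speak of the compounds shown alone.

In a functional assay on A549 cells (Homo sapiens) for cytotoxicity, read by resazurin assay, with a stated time of 72 h (on this read-out higher numbers stand for weaker inhibition and lower numbers for stronger inhibition), compound 1 (`N#Cc1cc(-c2ccccc2)n(-c2ccccn2)c1N`) gives 32000 nM, the higher of the two numbers measured, while compound 2 (`N#Cc1cc(-c2ccccc2)n(-c2ccc(Cl)cc2)c1N`) gives 7700 nM. Compound 3 (`Nc1c(-c2nc3ccccc3[nH]2)cc(-c2ccccc2)n1-c1ccccn1`) departs from compound 1 at a different place: 1H-benzimidazol-2-yl in place of cyano on an aromatic carbon. The new group stands on an aromatic carbon, next to the ring atom that bears an amino group. Among the compounds with values here, the only measured step, a 4.2-fold lower number from compound 1 to compound 2 (0.62 log units; beyond the scatter), is a change on an aromatic nitrogen, so it offers a guide to size and does not test this position. With compound 1 at 32000 nM and a much larger group entering, a lower number seems the likelier direction, though this remains uncertain. The expected change is a 3.6-fold lower number from compound 1 to compound 3 (0.55 log units; beyond the scatter), similar in size to the measured step. Compound 3 is estimated at 9000 nM, with an expected range from 2000 nM to 35000 nM.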

Compound 3, half-maximal inhibitory concentration: 8000 nM
Compound 3: the middle estimate sits 1.1-fold (0.05 log units) above what was measured, within the range that was stated.
By their numbers in this assay, from the lowest: compounds 2 and 3 (each within the scatter of the next); then compound 1.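

Within the data shown here, replacing cyano with 1H-benzimidazol-2-yl gives the first reading in this assay for this aromatic carbon, next to the ring atom that bears an amino group (a 4.0-fold lower number from compound 1 to compound 3 (0.60 log units; beyond the scatter)). This shows that the position can take a much larger group on the core of compound 1 and that the number falls rather than rises on this read-out. No measurement shown here accounts for the shift.

Going by these compounds, whether the shift requires the whole 1H-benzimidazol-2-yl group remains open, as does what a smaller imidazol-2-yl group, a carboxylic acid or an amide would do on the same carbon. Also open, on these data alone, is whether this change would hold with 4-chlorophenyl in place of pyridin-2-yl on the ring nitrogen, and whether the same direction would appear in cells other than this single line.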